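The compounds below may be only part of what the source reports. "The series", "measured", "known", "first", "only" and "open" are said of these compounds alone.

Measured so far, all in a functional assay on A549 cells (Homo sapiens) for cytotoxicity, read by MTT assay, with a stated time of 72 h; a lower number here means a stronger inhibitor, a higher number a weaker inhibitor:

Compound 1, `COc1cc2c(Oc3ccc(NC(=O)c4cn(-c5ccccc5C)nn4)cc3F)ccnc2cc1OCCCN1CCC(C)CC1`, gives 3500 nM.
Compound 2, `COc1cc2c(Oc3ccc(NC(=O)c4cn(-c5c(C)cccc5C)nn4)cc3F)ccnc2cc1OCCCN1CCC(C)CC1`, gives 3340 nM.
Compound 3, `COc1cc2c(Oc3ccc(NC(=O)c4cn(-c5ccccc5C)nn4)cc3F)ccnc2cc1OCCCN1CCN(C)CC1`, gives 3100 nM.

Going by the values given here, all three numbers sit close together, and no pair of them is separated by more than the usual scatter of this assay, so none of the three can be called stronger or weaker than another.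

Compound 1 and compound 2 differ in one place: methyl in place of hydrogen on an aromatic carbon. The step that went with this change was a 1.0-fold lower number from compound 1 to compound 2 (0.02 log units; within the scatter). Compound 1 and compound 3 differ in a different place: 4-methylpiperazin-1-yl in place of 4-methylpiperidin-1-yl on a saturated chain carbon, three bonds along the chain from an oxygen on an aromatic ring. That step was a 1.1-fold lower number from compound 1 to compound 3 (0.05 log units; within the scatter).

Compound 4, `COc1cc2c(Oc3ccc(NC(=O)c4cn(-c5c(C)cccc5C)nn4)cc3F)ccnc2cc1OCCCN1CCN(C)CC1`, has not yet been measured. It is related to compound 3 by methyl in place of hydrogen on an aromatic carbon. This is the same change as the one from compound 1 to compound 2, made on the core of compound 3 rather than the core of compound 1; how these two cores differ is given above by the change from compound 1 to compound 3. Since the earlier instance of the change stayed within the scatter, the step from compound 3 to compound 4 is expected to be of about the same size, namely a 1.0-fold lower number from compound 3 to compound 4 (0.01 log units; within the scatter). On that basis compound 4 is expected to give about 3000 nM in this assay, likely between 1500 nM and 6000 nM.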

Compound 4, half-maximal inhibitory concentration: 2180 nM
The estimate for compound 4 lay 1.4-fold (0.14 log units) above the measured number; the measured number falls inside the stated range.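

In this assay, turning 2-methylphenyl into 2,6-dimethylphenyl on the core of compound 3 went with a 1.4-fold lower number from compound 3 to compound 4 (0.15 log units; within the scatter), and this agrees with the same change made on the core of compound 1: the same change on two cores in this assay, a 1.0-fold lower number (0.02 log units; within the scatter) from compound 1 to compound 2 and a 1.4-fold lower number (0.15 log units; within the scatter) from compound 3 to compound 4, 1.4-fold (0.13 log units) apart, within the scatter of two such steps

Putting 4-methylpiperazin-1-yl in place of 4-methylpiperidin-1-yl went with a 1.5-fold lower number from compound 2 to compound 4 (0.19 log units; within the scatter), and this also agrees with its earlier instance: the same change on two cores in this assay, a 1.1-fold lower number (0.05 log units; within the scatter) from compound 1 to compound 3 and a 1.5-fold lower number (0.19 log units; within the scatter) from compound 2 to compound 4, 1.4-fold (0.13 log units) apart, within the scatter of two such steps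

Across these four compounds, then, each change carried from one core to the other as a step too small to tell from the scatter, so nothing here suggests that the effect of one change depends on the other, but this does not show that either change has no effect, and a small dependence could go unseen among steps of this size.

The compounds shown leave open whether a larger group in place of the added methyl, such as ethyl or chlorine, would give a step beyond the scatter. They also leave open what a different amine at the end of the chain, such as morpholin-4-yl, or a longer chain would do, and whether either change would carry over in the same way on such compounds.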